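From 3-methoxyphenyl to benzyl on the amide nitrogen

The source may report more compounds than this note shows. Statements on the series, on what has been measured and on what is new or still open speak of the compounds shown alone.

In a functional assay on U-937 cells (Homo sapiens), read by cAMP accumulation (on this read-out lower numbers stand for an effect already at smaller amounts and higher numbers for an effect only at larger amounts of compound), compound 1 (`CCc1nn(-c2ccc(F)cc2)c2c1CCN(c1cccc(C)c1)C2=O`) gives 780 nM and compound 3 (`CCCCc1nn(-c2ccc(F)cc2)c2c1CCN(c1ccccc1)C2=O`) gives 13000 nM as working reference points. Compound 2 (`CCc1nn(C2CCCC2)c2c1CCN(c1cccc(OC)c1)C2=O`) has the lowest number of the three at 330 nM in this series. Compound 1 is its nearest neighbour and compound 3 its furthest, and both gaps lie beyond the scatter. Within the data shown here, the three measured compounds differ from one another in more than one place, so no measured pair isolates a single group.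

Compound 4 (`CCc1nn(C2CCCC2)c2c1CCN(Cc1ccccc1)C2=O`) departs from compound 2 in one place only (benzyl in place of 3-methoxyphenyl on an amide-type nitrogen in a ring) with benzyl in place of 3-methoxyphenyl on an amide-type nitrogen in a ring. Among the measured compounds shown here, no measured compound carries benzyl at that place, so the data offer no direct guide to this change. Compound 2 at 330 nM already holds the lowest number, and compound 3 at 13000 nM shows how far numbers reach among these compounds, so a rise is judged more likely than a fall. An upward step beyond the scatter is expected (a 6.1-fold higher number from compound 2 to compound 4 (0.78 log units; beyond the scatter)) with wide uncertainty. Compound 4 is estimated at 2000 nM with a range of 400 nM to 10000 nM as the expected bounds.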

Compound 4, half-maximal effective concentration: 36 nM
Compound 4: middle estimate off by 56-fold (1.74 log units), on the high side, and the stated range ends above it.
By their numbers in this assay, from the lowest: compound 4; then compound 2; then compound 1; then compound 3.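

Among these compounds, with the rest of the molecule held fixed in this assay, benzyl in place of 3-methoxyphenyl on the amide-type nitrogen in a ring gives a 9.2-fold lower number from compound 2 to compound 4 (0.96 log units; beyond the scatter) as the first single-place step, and compound 4 now has the lowest number of the four. Compounds 1, 2 and 3 all carry a phenyl-type ring directly on this nitrogen, so they gave no view of a benzyl group here, and compound 4 shows that this place accepts it with a lower number than compound 2. Among the compounds shown here, the single step both replaces 3-methoxyphenyl with benzyl and removes the methoxy oxygen, and the available information neither separates these two parts nor offers any measured explanation for the step.

The compounds shown leave open whether 3-methoxybenzyl on this nitrogen would keep the number of compound 4 or move it, which would show whether the methoxy group matters once benzyl is present. They also leave open how 2-phenylethyl, a longer chain carrying the same ring, would compare with benzyl at this place on the otherwise unchanged core of compound 4.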